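Piperidinyl substitution on the benzimidazole of compound 2

A few compounds are considered here, and "the series" means these few. Any claim that something is new, unique, unknown or untested is made for them only; others in the source may bear on it.

Three members of the series have been run in an ADME assay on microsomes from liver (Homo sapiens) for metabolic stability, read by LC-MS, using NADPH, with a stated time of 15 min, tested at 1 uM; a lower number here means slower removal, a higher number faster removal of the compound. Compound 1 `Cc1nc(C)n(CC(=O)N2CCN(c3sc(C(F)(F)F)nc3-c3nc4ccc(C5CCOCC5)cc4[nH]3)C[C@H]2C)n1` gives 18 mL.min-1.g-1 in this assay. Compound 2 `Cc1nc(C)n(CC(=O)N2CCN(c3sc(C(F)(F)F)nc3-c3nc4ccccc4[nH]3)C[C@H]2C)n1` gives 30 mL.min-1.g-1, and compound 3 `C[C@@H]1CN(c2sc(C(F)(F)F)nc2-c2nc3ccccc3[nH]2)CCN1C(=O)Cn1cnc2c1CCN(C)C2` gives 21 mL.min-1.g-1. Compound 2 is separated from both neighbours by steps inside the scatter: a 1.7-fold higher number from compound 1 to compound 2 (0.22 log units; within the scatter) and a 1.4-fold lower number from compound 2 to compound 3 (0.15 log units; within the scatter), so no ordering among the three can be claimed.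

Compound 4 `Cc1nc(C)n(CC(=O)N2CCN(c3sc(C(F)(F)F)nc3-c3nc4ccc(C5CCN(C)CC5)cc4[nH]3)C[C@H]2C)n1` is the next candidate. It differs from compound 2 in one place: 1-methylpiperidin-4-yl in place of hydrogen on an aromatic carbon. For the measured compounds named here, the measured step that bears on this is the one from compound 1 to compound 2, where an oxan-4-yl at the same aromatic carbon was exchanged for hydrogen, and that change left the number within scatter, a 1.7-fold higher number from compound 1 to compound 2 (0.22 log units; within the scatter). The step from compound 2 to compound 3 concerns a different part of the molecule and is also within scatter. With only this to go on, the number for compound 4 is expected to stay close to that of compound 2, with an expected step of a 1.4-fold lower number from compound 2 to compound 4 (0.13 log units; within the scatter). Compound 4 is estimated at 22 mL.min-1.g-1 in this assay, within a range of 9 mL.min-1.g-1 to 50 mL.min-1.g-1.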

Compound 4, intrinsic clearance in microsomes: 27 mL.min-1.g-1
Compound 4: the middle estimate sits 1.2-fold (0.09 log units) below what was measured, and the stated range covers the measured number.
By their numbers in this assay, from the lowest: compounds 1, 3, 4 and 2 (each within the scatter of the next).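

In this assay, this aromatic carbon now carries 1-methylpiperidin-4-yl, and the exchange for hydrogen stays within the scatter (a 1.1-fold lower number from compound 2 to compound 4 (0.05 log units; within the scatter)). Exchanging oxan-4-yl for 1-methylpiperidin-4-yl at the same carbon also stays within the scatter (a 1.5-fold higher number from compound 1 to compound 4 (0.18 log units; within the scatter)), so hydrogen and these two six-membered non-aromatic rings are not told apart at this position in compounds 1, 2 and 4. No supporting measurement is available to explain this result.

Still open, on these data alone, is whether a carboxylic acid or an open-chain primary amine on this aromatic carbon would give a step beyond the scatter. Also open, as far as these compounds go, is whether 1-methylpiperidin-4-yl would behave the same way on compound 3, with its different group on the carbonyl side.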